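Oxygen to Sulfur in a Carbamate: Expected Receptor Binding

This account rests on a few compounds, and the source may have more. Where it says the series, first, only, none or still open, it means among the compounds named here.

Compound 3 `CN(C)C(=O)OC[C@H]1OC(n2cnc3c(NC4CCOC4)ncnc32)[C@H](O)[C@@H]1O` was measured in an assay on DDT1 cells (Cricetulus griseus) for binding affinity to adenosine receptor A1 (Homo sapiens), read by radioligand binding (on this read-out lower numbers stand for stronger inhibition and higher numbers for weaker inhibition), where compound 3 gives 238 nM. Among the three measured compounds this is the highest number, yet it lies within the scatter of both of the others: compound 1 `CCCC/N=C(\S)OC[C@H]1OC(n2cnc3c(NC4CCOC4)ncnc32)[C@H](O)[C@@H]1O` gives 157 nM and compound 2 `O[C@@H]1[C@@H](CO/C(S)=N/C2CCC2)OC(n2cnc3c(NC4CCOC4)ncnc32)[C@@H]1O` gives 148 nM. The step of a 1.5-fold higher number from compound 1 to compound 3 (0.18 log units; within the scatter) and the step of a 1.6-fold higher number from compound 2 to compound 3 (0.21 log units; within the scatter) each exchange a sulfur-containing group of 7 heavy atoms for the dimethylcarbamoyl group, and neither moved the number beyond the scatter; the step of a 1.1-fold lower number from compound 1 to compound 2 (0.03 log units; within the scatter) was equally flat.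

Compound 4 `CN(C)C(=S)OC[C@H]1OC(n2cnc3c(NC4CCOC4)ncnc32)[C@H](O)[C@@H]1O` differs from compound 3 by a group of 5 heavy atoms (3 carbon, 1 nitrogen, 1 sulfur; no ring) in place of a group of 5 heavy atoms (3 carbon, 1 nitrogen, 1 oxygen; no ring), on an oxygen on a saturated carbon. Among the measured compounds shown here, no measured step makes exactly this exchange of oxygen for sulfur while keeping the rest of the group unchanged. The two steps that bring sulfur in or take it out at this place, from compound 1 and from compound 2 to compound 3, stayed within the scatter, so no step beyond the scatter is expected in this assay here either. Compound 4 is therefore expected to give about 200 nM, with a range from 90 nM to 450 nM. This corresponds to an expected step of a 1.2-fold lower number from compound 3 to compound 4 (0.08 log units; within the scatter), within the scatter.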

Compound 4, inhibition constant: 205 nM
The estimate for compound 4 lay 1.0-fold (0.01 log units) below the measured number, and the stated range covers the measured number.
By their numbers in this assay, from the lowest: compounds 2, 1, 4 and 3 (each within the scatter of the next).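

In this assay, the exchange of oxygen for sulfur in the dimethylcarbamoyl group can now be read on its own, and a 1.2-fold lower number from compound 3 to compound 4 (0.06 log units; within the scatter) shows that this single change at this place stays within the scatter. The group with 5 heavy atoms that carries sulfur also cannot be told apart from the two sulfur-bearing groups with 7 heavy atoms, as shown by a 1.4-fold higher number from compound 2 to compound 4 (0.14 log units; within the scatter) and a 1.3-fold higher number from compound 1 to compound 4 (0.12 log units; within the scatter), so changing the size of the group on this oxygen has shown no clear effect so far. No supporting data are available to explain why these numbers stay so close.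

The compounds shown leave open whether a group ending in an amine or a carboxylic acid, or a much longer chain, on this oxygen would also stay within the scatter. They also leave open whether exchanging oxygen for sulfur gives the same result on a different core.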